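The compounds below may be only part of what the source reports. "The series", "measured", "known", "first", "only" and "open" are said of these compounds alone.

Measured in an ADME assay on A549 cells (Homo sapiens) for inhibition, read by MTT assay; on this read-out lower numbers stand for stronger inhibition of growth and higher numbers for weaker inhibition of growth:
compound 1 `CCCCCCc1cc2c(=O)n(CCSc3nc(-c4cc(OC)c(OC)c(OC)c4)c(C#N)c(=O)[nH]3)cnc2s1`: 96.8 ug/mL
compound 2 `CCCCCCc1cc2c(=O)n(CCCSc3nc(-c4cc(OC)c(OC)c(OC)c4)c(C#N)c(=O)[nH]3)cnc2s1`: 90.2 ug/mL
compound 3 `CCCCCCCc1cc2c(=O)n(CCSc3nc(-c4cc(OC)c(OC)c(OC)c4)c(C#N)c(=O)[nH]3)cnc2s1`: 79.7 ug/mL

Compound 2 stands second highest of the three numbers; compound 1 and compound 3 both lie within the scatter of it, so no order among the three is set. Compound 4 `CCCc1cc2c(=O)n(CCCSc3nc(-c4cc(OC)c(OC)c(OC)c4)c(C#N)c(=O)[nH]3)cnc2s1` differs from compound 2 by hydrogen in place of propyl on a saturated chain carbon, three bonds along the chain from an aromatic carbon, a shorter chain on the shared core. Going by the values given here, the only measured step touching that chain is a 1.2-fold lower number from compound 1 to compound 3 (0.08 log units; within the scatter), a lengthening by one carbon that did not move the number. Among the compounds with values here, the shortening to compound 4 is larger than anything measured and no step bears on it directly. The expected step is a 1.2-fold higher number from compound 2 to compound 4 (0.07 log units; within the scatter), small, a slight rise allowed. The expected value for compound 4 in this assay is 105 ug/mL, within 60 ug/mL to 190 ug/mL.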

Compound 4, concentration for 50% growth inhibition: > 100 ug/mL
Compound 4 ended at the assay's limit (the forecaster's own chance of this, stated with the estimate: 20%); the middle value is on the limit's open side.
By their numbers in this assay, from the lowest: compounds 3, 2 and 1 (each within the scatter of the next). At a limit, above all of these: compound 4.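

Shortening hexyl to propyl on the shared core gives an at least 1.1-fold higher number from compound 2 to compound 4 (0.04 log units; that floor lies within the scatter), so only a floor is known for this change, and that floor stays within the scatter. Compound 4 reads > 100 ug/mL in this assay, which is a limit and not a number, and the true size of the step stays unset: the limit of > 100 ug/mL in this assay, at which 1 of the 4 values shown sits.

Going by these compounds alone, this is the first read on a shortening at this position, and it shows no sign that a shorter chain lowers the number. Open, on these data alone, is whether a chain longer than that of compound 3, or an amine or a carboxylic acid carried on that chain, would bring the number down.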